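The source may report more compounds than this note shows. Statements on the series, on what has been measured and on what is new or still open speak of the compounds shown alone.

Measured so far:
compound 1 `CC1C(=O)CC(c2ccc(F)cc2)N(C(=O)CN2CCN(C)CC2)C1c1ccc(Cl)cc1` — 65.5%
compound 2 `CC1C(=O)CC(c2ccc(F)cc2)N(C(=O)CCl)C1c1ccc(O)cc1` — 51.2%

In a functional assay on the whole organism for inhibition, with Mus musculus as the target, in the writhing test, with a stated time of 1 h, at a dose of 60 mg/kg by the oral route (a lower number here means less inhibition, a higher number more inhibition at the dose given (going by the name of the read-out)), compound 1 gives 65.5%, the higher of the two values recorded. Compound 2 gives 51.2% in this assay, a value lower than that of compound 1 by more than the usual scatter. Within the data shown here, the two compounds differ from each other in more than one place, so no single structural step between them can be read from their values.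

Compound 3 `COc1ccc(C2C(C)C(=O)CC(c3ccc(F)cc3)N2C(=O)CN2CCN(C)CC2)cc1` differs from compound 1 in one place only: methoxy in place of chloro on an aromatic carbon. Among the measured compounds shown here, no measured pair isolates this change, so the size of the step rests on expectation alone. The step expected in this assay is a number 7.5 percentage points lower from compound 1 to compound 3 (within the scatter), a small movement that may well fall within the scatter, with a slight lean downward. Compound 3 is expected to give 58% in this assay, within a range from 40% to 75%.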

Compound 3, a percentage reported as inhibition, in the whole organism at one dose (the size of the read-out at that dose, not a potency) in the Mus musculus assay: 55.2%
For compound 3 the middle estimate is 2.8 percentage points above the measured one; the measured number falls inside the stated range.
By their numbers in the Mus musculus assay, from the lowest: compounds 2 and 3 (each within the scatter of the next); then compound 1.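

In the Mus musculus assay the series now has its first single-place step, a number 10.3 percentage points lower from compound 1 to compound 3 (beyond the scatter), which shows that inhibition at the dose given responds to 4-chlorophenyl to 4-methoxyphenyl at this position, para to a large group. In a physicochemical assay for lipophilicity, using the shake flask method (a lower number here means a more polar compound, a higher number a more lipophilic compound), compound 1 gives 2.09 and compound 3 gives 1.53. The partition coefficient therefore falls along with inhibition, although this single pair cannot separate lipophilicity from any other consequence of the change: the measured partition coefficient of compound 1, 2.09, and of compound 3, 1.53, a number 0.56 log units lower (beyond the scatter)

Among these compounds, no step to compound 2 can be read, as it differs from compound 1 and compound 3 in more than one place. As far as these compounds go, whether inhibition tracks the partition coefficient or depends on the particular group stays open, and a nitrile or a trifluoromethyl group on the same aromatic carbon would help to test this.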